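The compounds below may be only part of what the source reports. "The series", "measured", "known", "first", "only" and "open" are said of these compounds alone.

Working notes on the series. In a functional assay on MCF7 cells (Homo sapiens) for cytotoxicity, read by sulforhodamine B assay, with a stated time of 48 h (a higher number here means a weaker inhibitor of growth, a lower number a stronger inhibitor of growth), compound 1 `COc1cc(/C(Cl)=C/C=C(\C#N)C(=O)c2c[nH]c3ccccc23)cc(OC)c1OC` gives 94300 nM. Compound 2 `COc1ccc(/C(Cl)=C/C=C(\C#N)C(=O)c2c(C)[nH]c3ccccc23)cc1` returns only a limit, > 100000 nM, in this assay. Compound 3 `COc1ccc2[nH]cc(C(=O)/C(C#N)=C/C=C(\Cl)c3ccc(OC)c(OC)c3)c2c1` likewise returns only a limit, > 100000 nM, so its standing on the numbers shown is unresolved beyond (the limit of > 100000 nM in this assay, at which 2 of the 3 values shown sit), and no measured compound differs from it in a single place. Compound 4 `COc1ccc2[nH]cc(C(=O)/C(C#N)=C/C=C(\Cl)c3ccc(Br)cc3)c2c1` is the next case: 4-bromophenyl in place of 3,4-dimethoxyphenyl on a double-bonded chain carbon bound to a chlorine atom and a double-bonded chain carbon. No measured step covers this change, so the numbers shown support no direction; the expected step that the limit leaves unreadable from compound 3 to compound 4 is no shift beyond the scatter. For compound 4 the estimate is 120000 nM, with a range of 30000 nM to 400000 nM, and a fair chance that only a limit is reported again.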

Compound 4, concentration for total growth inhibition: > 100000 nM
Compound 4 gave a limit, no number (the forecaster's own chance of this, stated with the estimate: 65%); the middle value does not contradict the limit.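

In this assay, for the compounds shown here, compound 3 and compound 4 both return only a limit, and no step between them can be read. As far as these compounds go, whether 4-bromophenyl in place of 3,4-dimethoxyphenyl shifts growth inhibition at all stays open.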